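Replacing chloro with methyl in a tight compound set

This account rests on a few compounds, and the source may have more. Where it says the series, first, only, none or still open, it means among the compounds named here.

In a functional assay on T47D cells (Homo sapiens) for cytotoxicity, read by MTT assay, with a stated time of 48 h (a lower number here means a stronger inhibitor, a higher number a weaker inhibitor), the measured compounds read as follows:
compound 1 `COc1ccc(NC(=S)N/N=C\c2ccnc3ccccc23)cc1` gives 1360 nM
compound 2 `Fc1ccc(NC(=S)N/N=C\c2ccnc3ccccc23)cc1` gives 1070 nM
compound 3 `S=C(N/N=C\c1ccnc2ccccc12)Nc1ccc(Cl)cc1` gives 1270 nM

The steps of a 1.1-fold lower number from compound 1 to compound 3 (0.03 log units; within the scatter) and a 1.2-fold higher number from compound 2 to compound 3 (0.07 log units; within the scatter) both stay within the scatter, so compound 3 cannot be ranked against either of the other two. The next structure, compound 4 `Cc1ccc(NC(=S)N/N=C\c2ccnc3ccccc23)cc1`, keeps the shared core and differs in one group: methyl in place of chloro on an aromatic carbon. This is methyl in place of chloro on an aromatic carbon, para to a large group. Among the compounds with values here, no measured step makes this exact exchange, so the evidence is indirect. It comes from the exchanges among methoxy, fluoro and chloro at that place, the two above and also a 1.3-fold lower number from compound 1 to compound 2 (0.10 log units; within the scatter), all of them small. No step beyond the scatter is therefore expected in this assay, and neither direction is favoured. What is expected is a 1.0-fold lower number from compound 3 to compound 4 (0.01 log units; within the scatter) and nothing larger. Compound 4 is expected at 1250 nM within an estimated range of 700 nM to 2200 nM.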

Compound 4, half-maximal inhibitory concentration: 1320 nM
Compound 4: middle estimate off by 1.1-fold (0.02 log units), on the low side; the measured number falls inside the stated range.
By their numbers in this assay, from the lowest: compounds 2, 3, 4 and 1 (each within the scatter of the next).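

In this assay, the 4-chlorophenyl to 4-methylphenyl exchange adds a group of carbon alone to the methoxy, fluoro and chloro already seen at this place, and it leaves the number within the scatter (a 1.0-fold higher number from compound 3 to compound 4 (0.02 log units; within the scatter)). The same holds against the other two compounds (a 1.2-fold higher number from compound 2 to compound 4 (0.09 log units; within the scatter); a 1.0-fold lower number from compound 1 to compound 4 (0.01 log units; within the scatter)), so all four substituents now read alike here and none of the four compounds can be ranked against another. Nothing available on the compounds gives a reason for this flat reading.

The compounds shown leave open whether any group at this place can move the number beyond the scatter, for example an amine, a carboxylic acid or a longer chain. They also leave open whether changes elsewhere on the shared core would matter more.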